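The source may hold more compounds than are shown below. What is called first, only, known or untested is meant among the compounds shown, and "the series" means these compounds.

Of the compounds shown here, three sharing one core have been measured in a functional assay on the whole organism (B cells) with Mus musculus as the target; a higher number here means a larger maximal response, a lower number a smaller maximal response. Compound 1 `Nc1nc(O)c2c(n1)n(C1OC(CO)[C@@H](O)[C@H]1O)c(=O)n2C/C=C/c1ccccc1` gives 73%. Compound 2 `[N-]=[N+]=NCC(O)Cn1c(=O)n(C2OC(CO)[C@@H](O)[C@H]2O)c2nc(N)nc(O)c21` gives 91%. Compound 3 `Nc1nc(O)c2c(n1)n(C1OC(CO)[C@@H](O)[C@H]1O)c(=O)n2CC(O)CO` gives 136%, the highest of the three, and both steps leading to it are beyond the scatter: a number 63 percentage points higher from compound 1 to compound 3 (beyond the scatter) and a number 45 percentage points higher from compound 2 to compound 3 (beyond the scatter). The smaller step is a number 18 percentage points higher from compound 1 to compound 2 (beyond the scatter).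

Compound 4 `Nc1nc(O)c2c(n1)n(C1OC(CO)[C@@H](O)[C@H]1O)c(=O)n2CC(O)CSc1ccccc1` is the next compound. It differs from compound 3 in one place: phenylsulfanyl in place of hydroxy on a saturated chain carbon, two bonds along the chain from an oxygen on a saturated carbon. Among the measured compounds shown here, the only measured step at this same place is the one from compound 2 to compound 3, where hydroxy arriving in place of azido raised the response by a large amount, so removing the hydroxy again would be expected to lower it. Compound 1, which carries 2-phenylethenyl at the same chain carbon, stands lowest of all. A downward step is therefore expected for compound 4, of a size estimated as a number 56 percentage points lower from compound 3 to compound 4 (beyond the scatter). In this assay compound 4 is estimated at 80%, with a range from 55% to 110%.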

Compound 4, largest response reached (reported as maximal response), in percent of the reference or control that the assay uses: 12%
Compound 4: the middle estimate sits 68 percentage points above what was measured, and the stated range ends above it.
By their numbers in this assay, from the lowest: compound 4; then compound 1; then compound 2; then compound 3.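

In this assay, phenylsulfanyl in place of hydroxy at this saturated chain carbon gives a number 124 percentage points lower from compound 3 to compound 4 (beyond the scatter) and leaves compound 4 the lowest of the four. Swapping azido for phenylsulfanyl at the same place gives a number 79 percentage points lower from compound 2 to compound 4 (beyond the scatter) and extends the order at this carbon to three groups, with hydroxy highest, then azido, then phenylsulfanyl. Compound 1 also carries a six-membered aromatic ring of carbon only, yet 1-hydroxy-2-(phenylsulfanyl)ethyl in place of 2-phenylethenyl gives a number 61 percentage points lower from compound 1 to compound 4 (beyond the scatter) and so the presence of such a ring does not alone set the response.

No measurement available here explains this fall. Still open, on these data alone, is whether an amine, a carboxylic acid or a phenoxy group at this carbon would stay near compound 3 or fall towards compound 4.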